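The source may hold more compounds than are shown below. What is called first, only, known or untested is meant among the compounds shown, and "the series" means these compounds.

Of the compounds shown here, three built on closely related cores have been tested in a functional assay on HCT-116 cells (Homo sapiens) for cytotoxicity, read by fluorescence and resazurin assay, with a stated time of 48 h (a lower number here means a stronger inhibitor, a higher number a weaker inhibitor), and all three sit at the limit of the measurement. Compound 1 `COc1ccc(/C=C/c2cc(/C=C/c3ccc(OC)cc3)nc(OCCCCCBr)n2)cc1` gives a limit, > 20000 nM, in this assay. Compound 2 `COc1ccc(/C=C/c2cc(/C=C/c3ccc(OC)cc3)nc(OCCCCBr)n2)cc1` also gives only a limit, > 20000 nM, in this assay. The change from compound 1 to compound 2 is bromo in place of bromomethyl on a saturated chain carbon, four bonds along the chain from an oxygen on an aromatic ring, and the step it made, a step that the two limits leave unreadable from compound 1 to compound 2, cannot be read because both values rest on (the limit of > 20000 nM in this assay, at which 3 of the 3 values shown sit). Compound 3 `COc1ccc(/C=C/c2cc(/C=C/c3ccc(OC)c(OC)c3)nc(OCCCCCCBr)n2)cc1OC` likewise gives a limit, > 20000 nM, in this assay; the difference between its core and the core of compound 1 is not broken down here. Compound 4 `COc1ccc(/C=C/c2cc(/C=C/c3ccc(OC)c(OC)c3)nc(OCCCCCBr)n2)cc1OC` has not yet been measured. It differs from compound 3 by bromo in place of bromomethyl on a saturated chain carbon, five bonds along the chain from an oxygen on an aromatic ring, the same kind of change as that from compound 1 to compound 2, but placed five bonds rather than four bonds along the chain from the oxygen on the aromatic ring. Since compound 3 gives > 20000 nM and the earlier step of this kind left both partners at the limit, the expected step is a step that the limit leaves unreadable from compound 3 to compound 4. Compound 4 is therefore estimated at 30000 nM, most likely reported again as a limit.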

Compound 4, half-maximal inhibitory concentration: > 20000 nM
Compound 4 ended at the assay's limit; the forecaster's own chance of this, stated with the estimate: 85%; the middle value lies beyond the limit too.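

Compound 3 and compound 4 both give only a limit in this assay, so the size of the step between them cannot be read: the limit of > 20000 nM in this assay, at which 4 of the 4 values shown sit.

The compounds shown leave open how strong any of them actually is in this assay, and whether chain length or the difference between the cores affects that strength.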